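A few compounds are considered here, and "the series" means these few. Any claim that something is new, unique, unknown or untested is made for them only; others in the source may bear on it.

Measured compounds:
Compound 1, `CC(C)(C)c1cn(Cc2cc(=O)oc3cc(O)ccc23)nn1`, in a functional assay on SW-620 cells (Homo sapiens) for inhibition, read by MTT assay, with a stated time of 72 h (a lower number here means a stronger inhibitor, a higher number a weaker inhibitor), gives > 100000 nM, a limit of the assay and not a number.
Compound 2, `O=c1cc(Cn2cc(CNS(=O)(=O)c3ccc(Cl)cc3)nn2)c2ccc(O)cc2o1`, in this assay gives > 100000 nM, likewise a limit.

Compound 2 therefore stands only at a limit, with no number to place it. For the measured compounds named here, the one further value shown, that of compound 1, is a limit as well, which is what the limit of > 100000 nM in this assay, at which 2 of the 2 values shown sit, records. Going by the values given here, no step between measured compounds that differ in one place exists.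

Compound 3, `O=c1cc(Cn2cc(CNS(=O)(=O)c3ccc([N+](=O)[O-])cc3)nn2)c2ccc(O)cc2o1`, differs from compound 2 by nitro in place of chloro on an aromatic carbon. With both measured values sitting at the limit, neither size nor direction of a step in this assay can be read from the data. The expected step that the limit leaves unreadable from compound 2 to compound 3 is none beyond the scatter, most likely ending again at a limit. For compound 3 the estimate in this assay is 150000 nM, with a range from 40000 nM to 1000000 nM.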

Compound 3, half-maximal inhibitory concentration: > 100000 nM
Compound 3 gave a limit, no number; the forecaster's own chance of this, stated with the estimate: 85%; the middle value does not contradict the limit.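

Compound 3 gives > 100000 nM in this assay, a limit and not a number. For the compounds shown here, no step from compound 2 to compound 3 can be read. The compounds shown leave open how they rank against one another and whether any change to the shared core would give a measurable value: the limit of > 100000 nM in this assay, at which 3 of the 3 values shown sit.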